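Adding a butyl chain to a series that barely moves

The compounds below may be only part of what the source reports. "The series", "measured", "known", "first", "only" and "open" are said of these compounds alone.

Of the compounds shown here, three have been measured in an ADME assay on MCF7-DOX cells (Homo sapiens) for cytotoxicity, read by MTT assay, with a stated time of 48 h; a lower number here means a stronger inhibitor, a higher number a weaker inhibitor. Compound 1 (`COc1cc(O)c(C(=O)/C=C/c2cccc(N3CCNCC3)c2)c(OC)c1`) gives 99200 nM, compound 2 (`COc1cc(O)c(C(=O)/C=C/c2cccc(N3CCN(C)CC3)c2)c(OC)c1`) gives 62200 nM, and compound 3 (`COc1ccc(C(=O)/C=C/c2cccc(N3CCNCC3)c2)c(OC)c1`) gives 95000 nM. Compound 1 therefore stands level with the other two, as both steps away from it stay within the scatter. Methyl in place of hydrogen on an amine nitrogen in a ring gives a 1.6-fold lower number from compound 1 to compound 2 (0.20 log units; within the scatter). Hydrogen in place of hydroxy on an aromatic carbon gives a 1.0-fold lower number from compound 1 to compound 3 (0.02 log units; within the scatter).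

Compound 4 (`CCCCc1c(OC)cc(OC)c(C(=O)/C=C/c2cccc(N3CCNCC3)c2)c1O`) has butyl in place of hydrogen on an aromatic carbon. Neither measured step tests a chain like this, so they offer only weak guidance. Butyl is a larger change than either of them, so a modest move to a lower number is expected, although no real change remains possible. The expected size is a 1.8-fold lower number from compound 1 to compound 4 (0.26 log units; within the scatter). For compound 4 the estimate is 55000 nM, with an expected range of 20000 nM to 120000 nM.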

Compound 4, half-maximal inhibitory concentration: > 100000 nM
Compound 4: no number, only a limit; the forecaster's own chance of this, stated with the estimate: 15%; middle value at least 1.8-fold (0.25 log units) away from the limit.
By their numbers in this assay, from the lowest: compounds 2, 3 and 1 (each within the scatter of the next). At a limit, above all of these: compound 4.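

In this assay compound 4 gives > 100000 nM as its result, which is a limit of the assay and not a number. Compound 1 gives 99200 nM without the butyl chain, so butyl on this aromatic carbon, ortho to a hydroxy group and para to a methoxy group, brings a number no lower from compound 1 to compound 4 (the limit leaves the size open). Among these compounds, this is the first result that bears on this carbon, and the only one that is not a number: the limit of > 100000 nM in this assay, at which 1 of the 4 values shown sits.

On these data alone, it remains open whether butyl moves the result at all, and whether a shorter chain such as ethyl would give a readable number here. An amine or a carboxylic acid on the same carbon would show whether any group at this place can lower the number.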